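The source may report more compounds than this note shows. Statements on the series, on what has been measured and on what is new or still open speak of the compounds shown alone.

Compound 1 `[O-][n+]1nc(NCc2ccccc2Cl)[n+]([O-])c2ccccc21`: in a functional assay on PC-3 cells (Homo sapiens) for cytotoxicity, read by MTT assay, with a stated time of 48 h (a higher number here means a weaker inhibitor, a lower number a stronger inhibitor), compound 1 gives 10600 nM.
Compound 2 `CCNc1n[n+]([O-])c2ccccc2[n+]1[O-]`: in this assay compound 2 gives 13300 nM.

Going by the values given here, of the two numbers so far, compound 2 holds the higher one, yet it sits within the scatter of compound 1. Among the compounds with values here, the only step measured is a 1.3-fold higher number from compound 1 to compound 2 (0.10 log units; within the scatter), a change of the group on the saturated chain carbon bound to the ring nitrogen that left the read-out essentially where it was.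

Compound 3 `CCCCCCCCNc1n[n+]([O-])c2ccccc2[n+]1[O-]` differs from compound 2 by hexyl in place of hydrogen on a saturated chain carbon, two bonds along the chain from a nitrogen on an aromatic ring. Within the data shown here, no measured step lengthens a chain at this place, so the evidence is indirect: the single step, a 1.3-fold higher number from compound 1 to compound 2 (0.10 log units; within the scatter), shows that replacing the group on that same chain did not move the number beyond the scatter. On that basis no step beyond the scatter is expected in this assay for compound 3. Compound 3 is therefore estimated at 12000 nM in this assay, with a range from 4000 nM to 36000 nM. That estimate corresponds to an expected step of a 1.1-fold lower number from compound 2 to compound 3 (0.04 log units; within the scatter).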

Compound 3, half-maximal inhibitory concentration: 18200 nM
Compound 3: middle estimate off by 1.5-fold (0.18 log units), on the low side; low and high end bracket the measured number.
By their numbers in this assay, from the lowest: compounds 1, 2 and 3 (each within the scatter of the next).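

Going by these compounds alone, this is the first step at this position that lengthens the chain: in this assay, hexyl in place of hydrogen gives a 1.4-fold higher number from compound 2 to compound 3 (0.14 log units; within the scatter), so this much added chain leaves the read-out within the scatter. Heptyl in place of 2-chlorophenyl gives a 1.7-fold higher number from compound 1 to compound 3 (0.23 log units; within the scatter), so in this assay a long open chain and a chlorinated aromatic group on this carbon cannot be told apart. Nothing measured here speaks to why the number stays within the scatter across such different groups.

The compounds shown leave open whether a longer chain would move the number beyond the scatter. They also leave open whether an amine or a carboxylic acid on this chain would do so.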